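The compounds below may be only part of what the source reports. "The series", "measured", "known", "first", "only" and "open" are said of these compounds alone.

Three compounds carrying the same trifluoromethyl hydrate hydroxamate-like cap on a seven-atom amide-linked chain have been examined in an assay on isolated protein for inhibition of histone deacetylase 8 (Homo sapiens), read by chemiluminescence, with a stated time of 3 h; a higher number here means a weaker inhibitor, a lower number a stronger inhibitor. Compound 1 `O=C(CCCCCCNC(=O)C(O)(O)C(F)(F)F)Nc1ncc(-c2ccc(Br)cc2)s1` gives 10000 nM. Compound 2 `O=C(CCCCCCNC(=O)C(O)(O)C(F)(F)F)Nc1ccc(Br)cc1` replaces the aminothiazole-bridged aryl of compound 1 with a directly attached 4-bromophenyl amide; in this assay compound 2 gives 11000 nM. Compound 3 `O=C(CCCCCCNC(=O)C(O)(O)C(F)(F)F)Nc1ncc(-c2ccc(O)cc2)s1` gives 30000 nM. Among these three numbers compound 2 sits second highest: its value and that of compound 1 lie within the scatter of each other, while the gap to compound 3 lies beyond it.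

Going by the values given here, the only single-point step available is a 3.0-fold higher number from compound 1 to compound 3 (0.48 log units; beyond the scatter), a change that has no direct counterpart in the move now considered. Compound 4 `O=C(CCCCCCNC(=O)C(O)(O)C(F)(F)F)Nc1ccc(Cl)cc1` differs from compound 2 by chloro in place of bromo on an aromatic carbon. Among the compounds with values here, no measured pair shows a halogen swapped for another halogen, so there is no precedent for the size or direction of the step in this assay, and the one step that exists concerns a different group. The expectation for compound 4 is therefore a step of no change at the digits printed from compound 2 to compound 4 (within the scatter), that is, nothing beyond the scatter. Compound 4 is estimated at 11000 nM, with a range from 5000 nM to 25000 nM.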

Compound 4, half-maximal inhibitory concentration: 52000 nM
Compound 4: the middle estimate sits 4.7-fold (0.67 log units) below what was measured, and the stated range ends below it.
By their numbers in this assay, from the lowest: compounds 1 and 2 (each within the scatter of the next); then compounds 3 and 4 (each within the scatter of the next).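

In this assay, exchanging one halogen atom for another, with no change in the count of rings, hydrogen-bond donors, hydrogen-bond acceptors or net charge, gives a 4.7-fold higher number from compound 2 to compound 4 (0.67 log units; beyond the scatter) and so moves the number beyond the scatter. Bromo and chloro therefore cannot be treated as interchangeable at this place, on an aromatic carbon para to a large group, which the earlier compounds could not show, as their only step, a 3.0-fold higher number from compound 1 to compound 3 (0.48 log units; beyond the scatter) on a different core, concerned hydroxy in place of bromo. Both replacements of bromo shown now raise the number, though each was seen on only one core, and nothing available bears on why the chloro compound reads higher.

As far as these compounds go, it remains open whether chloro in place of bromo would produce a step of similar size on the core of compound 1, where the 4-bromophenyl group is carried by a different connection to the amide. Also open, from the compounds shown here alone, is how the number would respond at this same place to iodo, fluoro, methyl or a nitrile, or to a plain hydrogen, any of which would show whether bromo is unusual or chloro is.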